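Replacing phenyl with ethyl on sulfur in a furan-bearing antagonist

This account rests on a few compounds, and the source may have more. Where it says the series, first, only, none or still open, it means among the compounds named here.

Of the compounds shown here, two have been measured in a functional assay on HEK293 cells for antagonist activity at proteinase-activated receptor 4 (Homo sapiens), read by FLIPR and calcium flux, with a stated time of 30 min; a lower number here means a stronger inhibitor, a higher number a weaker inhibitor. Compound 1 `COc1cc(OCc2ccccc2OC)c2cc(-c3cn4nc(OC)sc4n3)oc2c1` gives 19 nM. Compound 2 `c1ccc(Sc2nn3cc(-c4cc5ccccc5o4)nc3s2)cc1` gives 1900 nM, the higher of the two values and a gap beyond the scatter, so compound 2 is the weaker inhibitor of the pair. Compound 3 `CCSc1nn2cc(-c3cc4ccccc4o3)nc2s1` differs from compound 2 by ethyl in place of phenyl on a sulfur. Among the measured compounds shown here, no measured pair shows this change, so the step from compound 2 to compound 3 is expected to be small, most likely within the scatter, as a 1.3-fold lower number from compound 2 to compound 3 (0.10 log units; within the scatter). Compound 3 is therefore estimated at 1500 nM, between 400 nM and 6000 nM.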

Compound 3, half-maximal inhibitory concentration: 2900 nM
Beside the measured number, compound 3's estimate is 1.9-fold (0.29 log units) below it; measured number inside the range.
By their numbers in this assay, from the lowest: compound 1; then compounds 2 and 3 (each within the scatter of the next).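

Putting ethyl in place of phenyl on the sulfur gives a 1.5-fold higher number from compound 2 to compound 3 (0.18 log units; within the scatter) in this assay. The six-membered aromatic ring can therefore give way to a two-carbon chain at this sulfur with no difference that can be told from the scatter, so the two groups read alike here. No supporting evidence is available to explain this result.

Still open, from the compounds shown here alone, is how a longer chain such as butyl, or a benzyl group, would read on the same sulfur. Going by these compounds, whether a group on this sulfur can bring a number outside the scatter of these two also remains unknown.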